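The source may hold more compounds than are shown below. What is called first, only, known or untested is meant among the compounds shown, and "the series" means these compounds.

Working notes on the series.

Three compounds in an ADME assay on PBMC cells (Homo sapiens) for cytotoxicity (on this read-out lower numbers stand for higher toxicity in this test and higher numbers for lower toxicity in this test), share one core and differ only in the aryl ether. Compound 1 `CC(CCNC(=O)c1c(Cl)cncc1Cl)N1CCC(C(Oc2ccccn2)c2ccc(C(F)(F)F)cc2)CC1` gives 34100 nM; compound 2 `Cc1cccnc1OC(c1ccc(C(F)(F)F)cc1)C1CCN(C(C)CCNC(=O)c2c(Cl)cncc2Cl)CC1` gives 33000 nM; compound 3 `Cc1cccc(OC(c2ccc(C(F)(F)F)cc2)C2CCN(C(C)CCNC(=O)c3c(Cl)cncc3Cl)CC2)n1` gives 6700 nM. Compound 3 stands lowest of the three numbers: the step of a 4.9-fold lower number from compound 2 to compound 3 (0.69 log units; beyond the scatter) and the step of a 5.1-fold lower number from compound 1 to compound 3 (0.71 log units; beyond the scatter) both lie beyond the scatter, while the step of a 1.0-fold lower number from compound 1 to compound 2 (0.01 log units; within the scatter) does not.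

Compound 4 `CC(CCNC(=O)c1c(Cl)cncc1Cl)N1CCC(C(Oc2cc(Cl)ccn2)c2ccc(C(F)(F)F)cc2)CC1` is the next member. Its difference from compound 3 is the following.

4-chloropyridin-2-yl in place of 6-methylpyridin-2-yl on an oxygen on a saturated carbon

Among the compounds with values here, the steps that bear on this change are the two that alter the same pyridine ring: a 5.1-fold lower number from compound 1 to compound 3 (0.71 log units; beyond the scatter) and a 4.9-fold lower number from compound 2 to compound 3 (0.69 log units; beyond the scatter), each modest, each with compound 3 at the lower end. Within the data shown here, compound 4 keeps neither the methyl of compound 3 nor the hydrogen of compound 1 at that position, and a chlorine at another ring position has no measured precedent here. The expectation is therefore a move back toward the numbers of compound 1 and compound 2, of size a 2.2-fold higher number from compound 3 to compound 4 (0.35 log units; beyond the scatter), though with wide uncertainty. For compound 4 in this assay the estimate is 15000 nM, within a range from 5000 nM to 45000 nM.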

Compound 4, half-maximal cytotoxic concentration: 4260 nM
Beside the measured number, compound 4's estimate is 3.5-fold (0.55 log units) above it, and the stated range ends above it.
By their numbers in this assay, from the lowest: compounds 4 and 3 (each within the scatter of the next); then compounds 2 and 1 (each within the scatter of the next).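

In this assay the step of an 8.0-fold lower number from compound 1 to compound 4 (0.90 log units; beyond the scatter) shows that the 4-chloropyridin-2-yl ether also ends well under the unsubstituted ether, so the low end of the series no longer rests on 6-methylpyridin-2-yl alone, though compound 2 goes against any general link between a ring substituent and a lower number. 4-Chloropyridin-2-yl in place of 6-methylpyridin-2-yl gives a 1.6-fold lower number from compound 3 to compound 4 (0.20 log units; within the scatter) and so leaves the two groups unseparated on this read-out, while 4-chloropyridin-2-yl in place of 3-methylpyridin-2-yl gives a 7.7-fold lower number from compound 2 to compound 4 (0.89 log units; beyond the scatter) and thus a wider gap than either methyl isomer's gap to the other compounds. No measurement at hand offers a reason for these differences.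

The compounds shown carry chloro and methyl at different ring places, so the effect of the group and the effect of its place on the ring remain tangled. A 4-methylpyridin-2-yl or 6-chloropyridin-2-yl ether would pull these apart, and a ring bearing an amine or a carboxylic acid would test whether the low numbers hold beyond chloro and methyl.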